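A Pyrazole Regioisomer in the Cycloheptyl Urea Series

This account rests on a few compounds, and the source may have more. Where it says the series, first, only, none or still open, it means among the compounds named here.

Compound 1 `Cc1cc(C)c(NC(=O)N(Cc2ccc(-c3ccccn3)cc2)C2CCCCCC2)c(C)c1` and compound 2 `Cc1cc(C)c(NC(=O)N(Cc2ccc(-c3ccn(C)n3)cc2)C2CCCCCC2)c(C)c1` share one core and differ in a single place. In a functional assay on a cell-free system (plasma) with sterol O-acyltransferase, Soat (Rattus norvegicus) as the target (a higher number here means that more compound is needed for the effect, a lower number that less compound is needed), compound 1 gives > 1 mg/kg, which is a limit of the assay. In this assay compound 2 gives < 1 mg/kg, also a limit. The step of a number no higher from compound 1 to compound 2 (the limit leaves the size open) is thus open in size, as the limit of < 1 mg/kg in this assay, at which 1 of the 2 values shown sits, and the limit of > 1 mg/kg in this assay, at which 1 of the 2 values shown sits, show. Compound 3 `Cc1cc(C)c(NC(=O)N(Cc2ccc(-c3ccnn3C)cc2)C2CCCCCC2)c(C)c1` carries 1-methyl-1H-pyrazol-5-yl in place of 1-methyl-1H-pyrazol-3-yl on an aromatic carbon. Among the compounds with values here, no measured step moves a methylpyrazole between attachment points, so the expected step that the limit leaves unreadable from compound 2 to compound 3 rests on the open step alone. In this assay compound 3 is estimated at 0.9 mg/kg, between 0.2 mg/kg and 3 mg/kg.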

Compound 3, dose for half-maximal effect: < 1 mg/kg
Compound 3: a limit, no number; the forecaster's own chance of this, stated with the estimate: 50%; the middle value is on the limit's open side.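

In this assay compound 3 gives < 1 mg/kg, which is a limit. Putting 1-methyl-1H-pyrazol-5-yl in place of pyridin-2-yl gives a number no higher from compound 1 to compound 3 (the limit leaves the size open). Moving the attachment point from 1-methyl-1H-pyrazol-3-yl to 1-methyl-1H-pyrazol-5-yl, on the aromatic carbon para to a large group, therefore leaves the compound on the same side of that limit as compound 2, and on the other side from the pyridin-2-yl of compound 1. The steps to compound 3 cannot be read, because the values stand at a limit: the limit of < 1 mg/kg in this assay, at which 2 of the 3 values shown sit.

From the compounds shown here alone, whether the two methylpyrazoles differ at all stays open. So does what a pyridin-3-yl group or an unsubstituted pyrazole would give at this place.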